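Swapping a Distal Aryl Group and the Proton Read-out

The source may report more compounds than this note shows. Statements on the series, on what has been measured and on what is new or still open speak of the compounds shown alone.

Compound 1 `COc1cccc(CNCCCNc2ccnc3cc(Oc4ccc(Cl)cc4)ccc23)c1O` was examined in a physicochemical assay for acid dissociation, where compound 1 gives 9.28. Among the compounds with values here, the only other measured compound, compound 2 `COc1cccc(CNCCCNc2ccnc3cc(-c4cc(C(F)(F)F)cc(C(F)(F)F)c4)ccc23)c1O`, gives 9.47 in this assay; these two numbers lie within the usual scatter of each other, so no real difference between compound 1 and compound 2 can be claimed. Compound 3 `COc1cccc(CNCCCNc2ccnc3cc(Cc4ccc(F)cc4)ccc23)c1O` has not yet been measured. It differs from compound 1 in one place: 4-fluorobenzyl in place of 4-chlorophenoxy on an aromatic carbon. Within the data shown here, no measured pair shows the effect of a change at this place directly, so the expectation rests on compound 2, which carries a quite different group there. The expected step of a number 0.07 log units higher from compound 1 to compound 3 (within the scatter) is therefore small, not beyond the scatter, because compound 2 gives 9.47. Compound 3 is expected to give about 9.35 in this assay, with a likely range from 9 to 9.7.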

Compound 3, acid dissociation constant: 9.47
For compound 3 the middle estimate is 0.12 log units below the measured one; the range from low to high includes it.
By their numbers in this assay, from the lowest: compounds 1, 2 and 3 (each within the scatter of the next).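

In this assay, within the data shown here, the first direct comparison at this position is the exchange of 4-chlorophenoxy for 4-fluorobenzyl, which gives a number 0.19 log units higher from compound 1 to compound 3 (within the scatter). The two groups have the same count of heavy atoms, but they differ in their atoms: 4-chlorophenoxy has oxygen and chlorine and counts one hydrogen-bond acceptor, whereas 4-fluorobenzyl has fluorine and counts none. So, between this pair, this exchange on the aromatic carbon produces no difference that can be told from the scatter, and nothing available bears on why.

From the compounds shown here alone, it remains open whether a group of a different kind at this aromatic carbon, such as an amine or a carboxylic acid, would move the number beyond the scatter. The same question stands for a longer chain in place of the groups seen here.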